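A few compounds are considered here, and "the series" means these few. Any claim that something is new, unique, unknown or untested is made for them only; others in the source may bear on it.

Working notes on the series. In a functional assay for inhibition, with Rattus norvegicus as the target (on this read-out lower numbers stand for stronger inhibition and higher numbers for weaker inhibition), compound 1 `CC(C)(C)/N=c1\c(O)c(O)\c1=N/Cc1ccc(F)cc1F` gives 2100 nM and compound 2 `CC[C@H](C)/N=c1\c(O)c(O)\c1=N/Cc1ccc(C#N)cc1` gives 2200 nM; the two numbers sit within the scatter of each other, so neither is set apart from the other. Compound 3 `CN(C)c1c(NCc2ccc(C#N)cc2)c(=O)c1=O`, built on a differently arranged core, reaches only the limit of > 30000 nM in this assay, at which 1 of the 3 values shown sits, in this assay, a limit rather than a number. In this assay compound 3 gives > 30000 nM, a limit.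

Compound 4 `CC(C)(C)/N=c1\c(O)c(O)\c1=N/Cc1ccc(F)cc1` differs from compound 1 by hydrogen in place of fluoro on an aromatic carbon. Among the compounds with values here, no measured pair in the set spans a change of this kind, so there is no step to lean on. The step from compound 1 to compound 4 is expected to be small, a 1.4-fold higher number from compound 1 to compound 4 (0.15 log units; within the scatter), leaning toward weaker inhibition but hardly beyond the scatter. Compound 4 is therefore estimated at 3000 nM, within 1200 nM to 8000 nM.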

Compound 4, half-maximal inhibitory concentration: 1500 nM
Compound 4: middle estimate off by 2.0-fold (0.30 log units), on the high side, and the stated range covers the measured number.
By their numbers in this assay, from the lowest: compounds 4, 1 and 2 (each within the scatter of the next). At a limit, above all of these: compound 3.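

In this assay hydrogen in place of fluoro on this aromatic carbon, ortho to a large group, gives a 1.4-fold lower number from compound 1 to compound 4 (0.15 log units; within the scatter) and so no change beyond the scatter. The fluoro group at this position is therefore not required for the inhibition seen with compound 1. Nothing at hand bears on the reason for so small a step.

Still open, going by these compounds, is whether a larger group here, such as chloro, methoxy or trifluoromethyl, would move the number beyond the scatter. Also open, on these data alone, is what an amine or a carboxylic acid would do at this carbon.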